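This account rests on a few compounds, and the source may have more. Where it says the series, first, only, none or still open, it means among the compounds named here.

Compound 1 `O=C(Nc1cccnc1)NC1CCN(c2ncc(C(F)(F)F)cc2Cl)CC1` is the weaker of the two compounds measured in an assay on membranes from brain for binding affinity to Lysophosphatidylserine lipase ABHD12 (Mus musculus), read by fluorescence, with a stated time of 20 min, tested at 2 uM; a higher number here means a stronger effect of the compound at the concentration tested, a lower number a weaker effect: in this assay compound 1 gives 1%, while compound 2 `FC(F)(F)c1cnc(NCCCCNC(=S)Nc2cccnc2)c(Cl)c1` gives 12%, a gap beyond the usual scatter. Compound 3 `FC(F)(F)c1cnc(N2CCC(NC(=S)Nc3cccnc3)CC2)c(Cl)c1` differs from compound 1 in a single place: a group of 9 heavy atoms (6 carbon, 2 nitrogen, 1 sulfur; one six-membered aromatic ring with 1 hetero atom) in place of a group of 9 heavy atoms (6 carbon, 2 nitrogen, 1 oxygen; one six-membered aromatic ring with 1 hetero atom), on an amine nitrogen. Among the measured compounds shown here, no one-change step between measured compounds is known, so the size of this change is uncertain. Compound 2, which also carries the entering group, gives 12%, so a modest gain seems plausible. The step is expected to be small and upward, about a number 7 percentage points higher from compound 1 to compound 3 (within the scatter), close to the scatter. Compound 3 is therefore estimated at 8%, with a range of 0% to 25%.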

Compound 3, a percentage reported as inhibition, at one concentration (the size of the read-out at that concentration, not a potency): 89%
For compound 3 the middle estimate is 81 percentage points below the measured one; measured number outside the range, above it.
By their numbers in this assay, from the lowest: compound 1; then compound 2; then compound 3.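

In this assay exchanging the single oxygen of the (pyridin-3-yl)carbamoyl group for sulfur, on the same amine nitrogen, gives a number 88 percentage points higher from compound 1 to compound 3 (beyond the scatter) and so shows that this one atom can separate a near-absent effect from a strong one. The earlier compounds shown here, with no one-change step between them, gave no sign of a jump this large. No measurement at hand explains it. Going by these compounds, whether the sulfur-bearing group keeps this effect when its pyridin-3-yl ring is replaced by a phenyl ring, or when that ring carries an amine, remains open.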